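The source may hold more compounds than are shown below. What is called first, only, known or untested is meant among the compounds shown, and "the series" means these compounds.

Series notes. In a functional assay for agonist activity at G protein-coupled receptor 88 (Homo sapiens), read by HTRF and cAMP accumulation (on this read-out lower numbers stand for an effect already at smaller amounts and higher numbers for an effect only at larger amounts of compound), compound 2 `CCCc1ccc(-c2ccc(N(C[C@@H](N)[C@@H](C)CC)C(=O)[C@@H]3C[C@H]3c3ccccc3)cc2)cc1` gives 61 nM and compound 3 `CC[C@H](C)[C@H](N)CN(C(=O)[C@@H]1C[C@H]1c1ccccc1)c1ccc(-c2ccc(OC(F)(F)F)cc2)cc1` gives 170 nM, the higher of the two single numbers; the step of a 2.8-fold higher number from compound 2 to compound 3 (0.45 log units; beyond the scatter) lies beyond the scatter. Compound 1 `CC[C@H](C)[C@H](N)CN(C(=O)[C@@H]1C[C@H]1c1ccccc1)c1ccc(-c2ccccc2)cc1` gives 230 nM; 800 nM (2 entries) and because of the several entries of compound 1 in this assay, 230 nM; 800 nM (2 entries) it has no single number to compare. Compound 4 `CC[C@H](C)[C@H](N)CN(C(=O)[C@@H]1C[C@H]1c1ccccc1)c1ccc(-c2ccc(C(=O)N(C)C)cc2)cc1` differs from compound 3 by dimethylcarbamoyl in place of trifluoromethoxy on an aromatic carbon. Going by the values given here, no measured step covers this exchange; the only step at this position, from propyl to trifluoromethoxy, is the one above, and compound 1 with an unsubstituted ring spans a wide pair of entries. The step of a 1.8-fold higher number from compound 3 to compound 4 (0.25 log units; within the scatter) is therefore expected to stay near the scatter, with compound 4 estimated at 300 nM, range 100 nM to 900 nM, in this assay.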

Compound 4, half-maximal effective concentration: 980 nM
Estimate against measurement, compound 4: 3.3-fold (0.51 log units) below; the measured number lies above the stated range.
By their numbers in this assay, from the lowest: compound 2; then compound 3; then compound 4.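

Trifluoromethoxy and dimethylcarbamoyl match in heavy atoms and hydrogen-bond acceptors, yet in this assay the exchange at this aromatic carbon gives a 5.8-fold higher number from compound 3 to compound 4 (0.76 log units; beyond the scatter). Matching these counts therefore does not keep the number in place. Taken from propyl, the change gives a 16-fold higher number from compound 2 to compound 4 (1.21 log units; beyond the scatter), the only large step printed at this position.

Going by these compounds, how an amine, a carboxylic acid or a chain longer than propyl would read at this carbon stays open. The unsubstituted ring offers no single reference point: the several entries of compound 1 in this assay, 230 nM; 800 nM (2 entries)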